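Swapping the Methyl Ester Group for a Tert-Butyl Group

This account rests on a few compounds, and the source may have more. Where it says the series, first, only, none or still open, it means among the compounds named here.

Compound 1 `CC1=C(C(=O)OC(C)(C)C)C(c2ccco2)NC(=O)N1C` gives 54% in an assay on membranes from HeLa cells for displacement of a labelled ligand from adenosine receptor A3 (Homo sapiens), read by scintillation counting, with a stated time of 180 min, tested at 1 uM; on this read-out higher numbers stand for more inhibition at the one concentration tested (going by the name of the read-out) and lower numbers for less inhibition.
Compound 2 `CC1=C(C(=O)OC(C)(C)C)C(c2cccs2)NC(=O)N1C` gives 22% in this assay.
Compound 3 `COC(=O)C1=C(C)N(C)C(=O)NC1c1ccsc1` gives 22% in this assay.

Compound 3 stands level with compound 2 at the digits reported, and the two are together the lowest of the three numbers; compound 1 sits higher, beyond the scatter. Compound 4 `CC1=C(C(=O)OC(C)(C)C)C(c2ccsc2)NC(=O)N1C` is compound 3 with one change: tert-butyl in place of methyl on an oxygen next to a carbonyl group. Among the measured compounds shown here, the only measured step, a number 32 percentage points lower from compound 1 to compound 2 (beyond the scatter), concerns the ring on the saturated ring carbon and not the ester, so it does not bear on this change. Compound 2 already carries the tert-butoxycarbonyl group and gives the same number as compound 3. For the measured compounds named here, with no measured step on the ester itself, the step of a number 3 percentage points higher from compound 3 to compound 4 (within the scatter) is expected to stay within the scatter. Compound 4 is therefore estimated at 25%, between 5% and 50%.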

Compound 4, a percentage reported as inhibition, at one concentration (the size of the read-out at that concentration, not a potency): 14%
Compound 4: middle estimate off by 11 percentage points, on the high side, and the stated range covers the measured number.
By their numbers in this assay, from the lowest: compounds 4, 2 and 3 (each within the scatter of the next); then compound 1.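

Among the compounds shown here, the ester change can now be read directly for the first time: in this assay tert-butyl in place of methyl on an oxygen next to a carbonyl group gives a number 8 percentage points lower from compound 3 to compound 4 (within the scatter) and so the two esters cannot be told apart here. Thiophen-3-yl and thiophen-2-yl cannot be told apart either, with a number 8 percentage points lower from compound 2 to compound 4 (within the scatter) on the same tert-butyl ester. Furan-2-yl alone stands apart among these tert-butyl esters, shown by a number 40 percentage points lower from compound 1 to compound 4 (beyond the scatter) for thiophen-3-yl in its place.

No evidence here gives a cause for these numbers. On these data alone, whether a carboxylic acid or an amide in place of the ester would shift the number remains open.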